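Moving a methoxy group around the sulfonamide ring

The compounds below may be only part of what the source reports. "The series", "measured", "known", "first", "only" and "open" are said of these compounds alone.

Compound 3 `COc1cccc(S(=O)(=O)Nc2ccc3oc(-c4ccccc4)nc3c2)c1` carries a 3-methoxyphenyl on its sulfonyl sulfur. In an assay on cells for inhibition of HSP60/HSP10 (Homo sapiens), with a stated time of 60 min (a lower number here means a stronger inhibitor, a higher number a weaker inhibitor), compound 3 gives > 100000 nM, which is a limit of the assay rather than a measured number. Its two relatives share the same core. Compound 1 `Cc1cccc(S(=O)(=O)Nc2ccc3oc(-c4ccccc4)nc3c2)c1` gives > 100000 nM in this assay, also a limit. Within the data shown here, compound 2 `O=S(=O)(Nc1ccc2oc(-c3ccccc3)nc2c1)c1ccc(O)cc1` gives 88000 nM in this assay, the one value of the three that is a plain number. The step of an at least 1.1-fold lower number from compound 1 to compound 2 (0.05 log units; that floor lies within the scatter) and the step of an at least 1.1-fold higher number from compound 2 to compound 3 (0.05 log units; that floor lies within the scatter) are each only a floor, and the step that the two limits leave unreadable from compound 1 to compound 3 cannot be read at all, because of the limit of > 100000 nM in this assay, at which 2 of the 3 values shown sit.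

Compound 4 `COc1ccc(S(=O)(=O)Nc2ccc3oc(-c4ccccc4)nc3c2)cc1` differs from compound 3 only in where the methoxy sits: 4-methoxyphenyl in place of 3-methoxyphenyl on a sulfonyl sulfur. The three measured steps bear on this change only loosely. None of them shows that altering the phenyl ring on the sulfonyl sulfur moves the number beyond the scatter, and compound 2, with its 4-hydroxyphenyl, gives a weak number as well. For compound 4 the expected step is therefore a number no higher from compound 3 to compound 4 (the limit leaves the size open). Compound 4 is estimated at 100000 nM, within 50000 nM to 300000 nM, with a fair chance that this assay again reports only a limit.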

Compound 4, half-maximal inhibitory concentration: > 100000 nM
Compound 4 was reported as a limit; the forecaster's own chance of this, stated with the estimate: 60%; the middle value lies on the limit itself.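

Moving the methoxy group to give the 4-methoxyphenyl leaves compound 4 at a limit of this assay, just like compound 3 and compound 1, so neither the step from compound 3 nor the step from compound 1 to compound 4 can be read, because all three values rest on the same ceiling: the limit of > 100000 nM in this assay, at which 3 of the 4 values shown sit.

Among these compounds, the one new comparison that can be read is with the 4-hydroxyphenyl, where a methyl in place of hydrogen on the oxygen gives an at least 1.1-fold higher number from compound 2 to compound 4 (0.05 log units; that floor lies within the scatter); this is only a floor, so it does not show that adding the methyl weakens the compound. Among the compounds shown here, the only plain number among the four therefore remains that of compound 2, 88000 nM. The 4-methoxyphenyl adds a further limit and no measure of the effect of the methoxy position.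

From the compounds shown here alone, how far compound 1, compound 3 and compound 4 each lie beyond the limit stays unknown, and so does any real difference between the two methoxy placements. Going by these compounds, whether an amine or a carboxylic acid on this phenyl ring would give a readable number also remains open.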